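This account rests on a few compounds, and the source may have more. Where it says the series, first, only, none or still open, it means among the compounds named here.

Three compounds share one core and differ only in the group on a saturated chain carbon bound to a sulfur. In a functional assay on MCF7 cells (Homo sapiens) for antiproliferative activity, read by MTT assay, with a stated time of 72 h (on this read-out higher numbers stand for weaker inhibition and lower numbers for stronger inhibition), compound 1 `C/C(C#Cc1ccccc1)=N\N/C(N)=N/S(=O)(=O)c1cc(C)c(Cl)cc1SCc1ccccc1C(F)(F)F` gives 19000 nM, compound 2 `C/C(C#Cc1ccccc1)=N\N/C(N)=N/S(=O)(=O)c1cc(C)c(Cl)cc1SCc1ccccc1Cl` gives 114000 nM, and compound 3 `C/C(C#Cc1ccccc1)=N\N/C(N)=N/S(=O)(=O)c1cc(C)c(Cl)cc1SCc1ccc(Cl)cc1` gives 14000 nM. Compound 3 stands at the low end of these numbers: the step of a 1.4-fold lower number from compound 1 to compound 3 (0.13 log units; within the scatter) is within the scatter, while an 8.1-fold lower number from compound 2 to compound 3 (0.91 log units; beyond the scatter) lies beyond it. Compound 4 `C/C(C#Cc1ccccc1)=N\N/C(N)=N/S(=O)(=O)c1cc(C)c(Cl)cc1SCc1cccc2ccccc12` carries naphthalen-1-yl in place of 4-chlorophenyl on a saturated chain carbon bound to a sulfur. The two earlier exchanges at that chain carbon bear on this change, and they ranged from no shift to a modest one; no measurement involving naphthalen-1-yl exists. Compound 4 is therefore expected to give 14000 nM, within 5000 nM to 40000 nM, a step of no change at the digits printed from compound 3 to compound 4 (within the scatter) that is expected to stay within the scatter.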

Compound 4, half-maximal inhibitory concentration: 210000 nM
For compound 4 the middle estimate is 15-fold (1.18 log units) below the measured one; the whole stated range lies below it.
By their numbers in this assay, from the lowest: compounds 3 and 1 (each within the scatter of the next); then compounds 2 and 4 (each within the scatter of the next).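

At the saturated chain carbon bound to a sulfur, naphthalen-1-yl moves the number upward in this assay, with a 15-fold higher number from compound 3 to compound 4 (1.18 log units; beyond the scatter) and an 11-fold higher number from compound 1 to compound 4 (1.04 log units; beyond the scatter) both large, while a 1.8-fold higher number from compound 2 to compound 4 (0.27 log units; within the scatter) places it with the 2-chlorophenyl compound at the high end. A group with two aromatic rings therefore does not keep the low numbers, yet ring count alone does not sort the set, since 2-chlorophenyl has one ring. Nothing available explains this shift. The compounds shown leave open whether naphthalen-2-yl or cyclohexyl at this chain carbon would fall with compound 3 or with compound 4.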